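Cyanosulfanyl in place of formyl on two cores

The compounds below may be only part of what the source reports. "The series", "measured", "known", "first", "only" and "open" are said of these compounds alone.

Four compounds share one substituent change on the five-membered ring and fall into two pairs by core. Compound 1 `O=Cc1c(-c2ccc(F)cc2)nc2sc(Cc3ccc(Cl)cc3)nn12` and compound 3 `N#CSc1c(-c2ccc(F)cc2)nc2sc(Cc3ccc(Cl)cc3)nn12` share one core; compound 2 `O=Cc1c(-c2cc3ccccc3oc2=O)nc2sc(Cc3ccc(Cl)cc3)nn12` and compound 4 `N#CSc1c(-c2cc3ccccc3oc2=O)nc2sc(Cc3ccc(Cl)cc3)nn12` share the other. The difference between the two cores is not broken down here.

In a functional assay on L1210 cells (Mus musculus) for cytotoxicity, with a stated time of 48 h (on this read-out lower numbers stand for stronger inhibition and higher numbers for weaker inhibition), compound 1 gives 20000 nM. In this assay compound 3 gives 23000 nM. The change between them, (cyanosulfanyl in place of formyl on an aromatic carbon), yields a 1.2-fold higher number from compound 1 to compound 3 (0.06 log units; within the scatter). In this assay compound 2 gives 890 nM, the lowest of the three measured numbers, beyond the scatter from both compound 1 and compound 3.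

Compound 4 carries the same kind of change on the second core: cyanosulfanyl in place of formyl on an aromatic carbon. Around the place, the two descriptions differ only in that the ring atom bearing the group carries a large group in compound 2, where in compound 1 it carries a 4-fluorophenyl group (7 heavy atoms). One measured instance of this change exists, and it stays within the scatter. For compound 4 the expected step is a 1.2-fold higher number from compound 2 to compound 4 (0.09 log units; within the scatter), set beside the measured 1.2-fold higher number from compound 1 to compound 3 (0.06 log units; within the scatter), and it rests on the fact that a 1.2-fold higher number from compound 1 to compound 3 (0.06 log units; within the scatter) lies within the scatter, with no second instance to test whether the core alters the outcome. Compound 4 is therefore estimated at 1100 nM in this assay, with a range from 400 nM to 3000 nM.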

Compound 4, half-maximal inhibitory concentration: 1300 nM
Beside the measured number, compound 4's estimate is 1.2-fold (0.07 log units) below it; the measured number falls inside the stated range.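

In this assay, cyanosulfanyl in place of formyl gives a 1.5-fold higher number from compound 2 to compound 4 (0.16 log units; within the scatter), so on this second core the exchange again leaves the number within the scatter. Set beside the first core, the two steps show no sign that the core alters the outcome of the change: the same change on two cores in this assay, a 1.2-fold higher number (0.06 log units; within the scatter) from compound 1 to compound 3 and a 1.5-fold higher number (0.16 log units; within the scatter) from compound 2 to compound 4, 1.3-fold (0.10 log units) apart, within the scatter of two such steps. Within the data shown here, this holds at two quite different levels of the read-out, with compound 2 at 890 nM and compound 1 at 20000 nM, but it rests on only two pairs in this assay, so it supports carrying the change between these two cores and not a general rule for the series, and it gives no account of how either group acts in the cells.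

Still open, going by these compounds, is whether other groups at this place, on an aromatic carbon of the five-membered aromatic ring, such as a carboxylic acid, an aminomethyl group or a longer acyl chain, would also stay within the scatter of formyl. Also open, on these data alone, is whether the exchange stays as quiet on a further core, for instance one carrying a pyridyl group where compound 1 has its 4-fluorophenyl group.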